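The compounds below may be only part of what the source reports. "The series", "measured", "known", "first", "only" and "open" are said of these compounds alone.

Measured compounds in an assay for binding affinity to 17-beta-hydroxysteroid dehydrogenase type 2 (Homo sapiens), with a stated time of 20 min, tested at 1 uM; on this read-out higher numbers stand for more inhibition at the one concentration tested (going by the name of the read-out) and lower numbers for less inhibition:
- compound 1 `O=[N+]([O-])c1ccc(-c2ccc3c(O)cccc3c2)cc1`: 13%
- compound 2 `CC(=O)c1ccc(-c2ccc3c(O)cccc3c2)cc1`: < 10%

Compound 1 and compound 2 share the same core and differ only in the group on the aromatic carbon. In this assay compound 1 gives 13%. For compound 2 the assay reports only a limit, < 10%, which is the limit of < 10% in this assay, at which 1 of the 2 values shown sits. For the measured compounds named here, the single measured step, a number at least 3 percentage points lower from compound 1 to compound 2 (that floor lies within the scatter), therefore has no exact size, only a floor, and that floor lies within the scatter. Compound 2 thus stands at the limit of this assay and carries no number of its own.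

Compound 3 `CS(=O)(=O)Nc1ccc(-c2ccc3c(O)cccc3c2)cc1` is not yet measured in this assay. Its change from compound 2 is methanesulfonamido in place of acetyl on an aromatic carbon. Going by the values given here, no measured step carries this change; the only step known, a number at least 3 percentage points lower from compound 1 to compound 2 (that floor lies within the scatter), concerns acetyl in place of nitro and does not bear directly on methanesulfonamido. With compound 2 already at the limit, the step expected is a number no lower from compound 2 to compound 3 (the limit leaves the size open), that is, none beyond the scatter. Compound 3 is accordingly estimated at 10%, in the range 0% to 25%, with a fair chance that the assay again reports only a limit.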

Compound 3, a percentage reported as inhibition, at one concentration (the size of the read-out at that concentration, not a potency): 75%
The estimate for compound 3 lay 65 percentage points below the measured number, and the stated range ends below it.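

In this assay, the group on this aromatic carbon, para to a large group, can shift the read-out far beyond the scatter, which the nitro and acetyl pair did not show: methanesulfonamido in place of nitro gives a number 62 percentage points higher from compound 1 to compound 3 (beyond the scatter). Methanesulfonamido in place of acetyl gives a number at least 65 percentage points higher from compound 2 to compound 3 (beyond the scatter). That step is known only as a floor, since the value of compound 2 is a limit and not a number: the limit of < 10% in this assay, at which 1 of the 3 values shown sits.

The change from acetyl to methanesulfonamido adds heavy atoms, brings in sulfur and nitrogen, and adds 1 hydrogen-bond donor, and the compounds shown do not separate these differences from one another. An acetamido group or an amine at this place, or a longer chain on the sulfonyl in place of the methyl, would help to tell them apart, while the read-out at a single concentration leaves the potency of compound 3 open.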